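The source may hold more compounds than are shown below. What is called first, only, known or untested is meant among the compounds shown, and "the series" means these compounds.

Three compounds in this series share one core and differ only in the aryl group on the triazole nitrogen. In a functional assay on A549 cells (Homo sapiens) for inhibition, read by MTT assay, with a stated time of 24 h (a higher number here means a weaker inhibitor, a lower number a stronger inhibitor), compound 1 `COc1ccc(-n2cc(CN3C(=O)C[C@@H]4CC[C@@]3(C)C4(C)C)nn2)cc1` gives 50 nM, compound 3 `CC1(C)[C@H]2CC[C@]1(C)N(Cc1cn(-c3ccccc3Br)nn1)C(=O)C2` gives 130 nM, and compound 2 `Cc1ccc(-n2cc(CN3C(=O)C[C@@H]4CC[C@@]3(C)C4(C)C)nn2)cc1` gives 400 nM. Compound 2 thus holds the highest number of the three: the step of an 8.0-fold higher number from compound 1 to compound 2 (0.90 log units; beyond the scatter) and the step of a 3.1-fold lower number from compound 2 to compound 3 (0.49 log units; beyond the scatter) both place it as the weakest inhibitor, with each gap beyond the scatter.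

Compound 4 `CC1(C)[C@H]2CC[C@]1(C)N(Cc1cn(-c3ccccc3Cl)nn1)C(=O)C2` follows from compound 2 by a single change: 2-chlorophenyl in place of 4-methylphenyl on an aromatic nitrogen. The step that bears most directly on it is the one in which a 2-bromophenyl replaced the same 4-methylphenyl, a 3.1-fold lower number from compound 2 to compound 3 (0.49 log units; beyond the scatter), a modest lowering; the related step of a 2.6-fold higher number from compound 1 to compound 3 (0.41 log units; beyond the scatter) shows that the 2-bromophenyl analogue sat between the two para-substituted compounds. From the compounds shown here alone, a 2-chlorophenyl has not been measured here, so its effect relative to 2-bromophenyl is unknown, but a lowering of similar size to that seen for compound 3 is expected in this assay.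

For compound 4 the estimated value in this assay is 150 nM, with a range from 60 nM to 400 nM, which would mean an expected step of a 2.7-fold lower number from compound 2 to compound 4 (0.43 log units; beyond the scatter).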

Compound 4, half-maximal inhibitory concentration: 70 nM
Compound 4: middle estimate off by 2.1-fold (0.33 log units), on the high side; low and high end bracket the measured number.
By their numbers in this assay, from the lowest: compounds 1, 4 and 3 (each within the scatter of the next, the first and the last beyond it); then compound 2.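

In this assay, the 2-chlorophenyl in place of the 4-methylphenyl gives a 5.7-fold lower number from compound 2 to compound 4 (0.76 log units; beyond the scatter) and so adds a second compound carrying a halogen-bearing aryl group that lies clearly apart from compound 2, which now stands beyond the scatter from all three others as the weakest inhibitor of the set. Chloro in place of bromo on the aromatic carbon gives a 1.9-fold lower number from compound 3 to compound 4 (0.27 log units; within the scatter) and stays within the scatter, so at this position the two halogens cannot be told apart in this measurement. The step of a 1.4-fold higher number from compound 1 to compound 4 (0.15 log units; within the scatter) also lies within the scatter, which puts the 2-chlorophenyl level with the 4-methoxyphenyl, although the 2-bromophenyl of compound 3 remains beyond the scatter from compound 1, so the three best compounds do not form one clean group.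

Because the 4-methylphenyl and 2-chlorophenyl differ in both the substituent and its place on the ring, these compounds cannot separate those two effects, and they leave open how a phenyl bearing an amine or a carboxylic acid, or a longer alkyl chain on the aromatic nitrogen, would behave. No measurement shown here offers an explanation for these differences.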